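A Triazole Aryl Swap on a Weakly Active Ester

A few compounds are considered here, and "the series" means these few. Any claim that something is new, unique, unknown or untested is made for them only; others in the source may bear on it.

Measured compounds:
- compound 1 `C/C(=C\CC/C(C)=C/CC[C@@H]1[C@@]2(C)CCC(=O)C(C)(C)[C@H]2CC[C@@]1(C)O)CC/C=C(\C)C(=O)OCc1cn(-c2ccccc2Cl)nn1`: in a functional assay on A549 cells (Homo sapiens) for antiproliferative activity, read by MTT assay, with a stated time of 48 h (a higher number here means a weaker inhibitor, a lower number a stronger inhibitor), compound 1 gives > 150000 nM, which is a limit of the assay.
- compound 2 `C#CCOC(=O)/C(C)=C/CC/C(C)=C/CC/C(C)=C/CC[C@@H]1[C@@]2(C)CCC(=O)C(C)(C)[C@H]2CC[C@@]1(C)O`: in this assay compound 2 gives 45100 nM.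
- compound 3 `C/C(=C\CC/C(C)=C/CC[C@@H]1[C@@]2(C)CCC(=O)C(C)(C)[C@H]2CC[C@@]1(C)O)CC/C=C(\C)C(=O)OCc1cn(-c2ccccc2Br)nn1`: in this assay compound 3 gives > 150000 nM, which is a limit of the assay.

Compound 3 stands only at a limit, and it shares that limit with compound 1 (the limit of > 150000 nM in this assay, at which 2 of the 3 values shown sit). The change of chloro to bromo gives a step that the two limits leave unreadable from compound 1 to compound 3. For the measured compounds named here, the only readable steps are an at least 3.3-fold lower number from compound 1 to compound 2 (0.52 log units; beyond the scatter) and an at least 3.3-fold higher number from compound 2 to compound 3 (0.52 log units; beyond the scatter), both of which exchange the whole triazolyl group for ethynyl and do not touch the substituent on the phenyl ring.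

Compound 4 `C/C(=C\CC/C(C)=C/CC[C@@H]1[C@@]2(C)CCC(=O)C(C)(C)[C@H]2CC[C@@]1(C)O)CC/C=C(\C)C(=O)OCc1cn(-c2cccc(C)c2)nn1` differs from compound 3 by 3-methylphenyl in place of 2-bromophenyl on an aromatic nitrogen. Going by the values given here, no measured step changes the substituent on that phenyl ring in a readable way, so nothing here lets a step be expected beyond the scatter. Compound 4 is therefore expected to remain near the limit, with an estimate of 120000 nM and a range from 40000 nM to 300000 nM. That estimate means an expected step of an at least 1.2-fold lower number from compound 3 to compound 4 (0.09 log units; that floor lies within the scatter).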

Compound 4, half-maximal inhibitory concentration: > 150000 nM
Compound 4: only a limit was reported (the forecaster's own chance of this, stated with the estimate: 60%); middle value at least 1.2-fold (0.09 log units) from the limit.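

In this assay compound 4 gives > 150000 nM, which is a limit of the assay, so 3-methylphenyl on the aromatic nitrogen, a group with no halogen, sits at the same limit as the two halogenated phenyl groups. The steps to compound 4 from compound 1 and from compound 3 cannot be read, as both ends of each are limits. The one readable exchange, 1-(3-methylphenyl)-1H-1,2,3-triazol-4-yl in place of ethynyl, gives an at least 3.3-fold higher number from compound 2 to compound 4 (0.52 log units; beyond the scatter), so all three triazolyl esters now lie on the same side of compound 2, and the limit holds most of the set: the limit of > 150000 nM in this assay, at which 3 of the 4 values shown sit.

As far as these compounds go, how compound 1, compound 3 and compound 4 rank among themselves stays unknown. Also open, from the compounds shown here alone, is whether a phenyl ring bearing an amine or a carboxylic acid would give a value inside the limit.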